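This account rests on a few compounds, and the source may have more. Where it says the series, first, only, none or still open, it means among the compounds named here.

Measured in an assay on cells with melanin-concentrating hormone receptor 1 (Homo sapiens) as the target, read by radioligand binding; on this read-out lower numbers stand for stronger inhibition and higher numbers for weaker inhibition:
Compound 1 `CC1CC1COc1cccc2ccc(N)nc12` gives 1640 nM.
Compound 2 `CCCOc1cccc2ccc(N)nc12` gives 1100 nM.
Compound 3 `CC(C)OCCOc1cccc2ccc(N)nc12` gives > 2000 nM, which is a limit of the assay and not a number.

Compound 3 thus stands at the limit of > 2000 nM in this assay, at which 1 of the 3 values shown sits, with no number of its own among the three. The steps toward it, an at least 1.8-fold higher number from compound 2 to compound 3 (0.25 log units; that floor lies within the scatter) and an at least 1.2-fold higher number from compound 1 to compound 3 (0.08 log units; that floor lies within the scatter), therefore set only floors, and both floors lie within the scatter. Compound 4 `CC(C)C(C)Oc1cccc2ccc(N)nc12` differs from compound 3 by 1,2-dimethylpropyl in place of 2-isopropoxyethyl on an oxygen on an aromatic ring. The change removes the isopropoxy-bearing chain and leaves a branched alkyl group on the aromatic oxygen, which brings compound 4 closer in kind to compound 1 and compound 2. Between those two alkyl ethers the step of a 1.5-fold lower number from compound 1 to compound 2 (0.17 log units; within the scatter) lies within the scatter, while the step of an at least 1.8-fold higher number from compound 2 to compound 3 (0.25 log units; that floor lies within the scatter) shows that attaching isopropoxy carried the value to the limit. Compound 4 is therefore expected to return to the range of compound 1 and compound 2, a step of roughly an at least 1.5-fold lower number from compound 3 to compound 4 (0.18 log units; that floor lies within the scatter). Compound 4 is estimated at 1300 nM, with a range from 500 nM to 3000 nM.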

Compound 4, half-maximal inhibitory concentration: 199 nM
Compound 4: the middle estimate sits 6.5-fold (0.82 log units) above what was measured, and the stated range ends above it.
By their numbers in this assay, from the lowest: compound 4; then compounds 2 and 1 (each within the scatter of the next). At a limit, above all of these: compound 3.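

In this assay, for the compounds shown here, 1,2-dimethylpropyl on an oxygen on an aromatic ring gives the first steps at this position that lie beyond the scatter with a number at both ends: a 5.5-fold lower number from compound 2 to compound 4 (0.74 log units; beyond the scatter) and an 8.2-fold lower number from compound 1 to compound 4 (0.92 log units; beyond the scatter). Going by these compounds alone, putting 1,2-dimethylpropyl in place of 2-isopropoxyethyl gives an at least 10-fold lower number from compound 3 to compound 4 (1.00 log units; beyond the scatter), whereas the earlier steps at this position, or their floors, all lay within the scatter. Compound 3 stands at a limit of the assay, so that last step is only a floor: the limit of > 2000 nM in this assay, at which 1 of the 4 values shown sits.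

The compounds shown leave open whether a smaller branched group such as isopropyl would read like 1,2-dimethylpropyl or like propyl in this assay. They also leave open how a longer chain, or an amine or a carboxylic acid on the chain, would read there.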